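Adding one methyl to compound 3

The source may report more compounds than this note shows. Statements on the series, on what has been measured and on what is new or still open speak of the compounds shown alone.

Values in a functional assay on HCT-116 cells (Homo sapiens) for antiproliferative activity (on this read-out higher numbers stand for weaker inhibition of growth and lower numbers for stronger inhibition of growth), so far:
compound 1 `Cc1ccnc2nc(-c3cccc(Cl)c3)cc(O)c12` gives 15.9 nM
compound 2 `Oc1cc(-c2ccc3ccccc3c2)nc2ncccc12` gives 3800 nM
compound 3 `Cc1ccnc2nc(-c3cccc4ccccc34)cc(O)c12` gives < 10 nM

Compound 3 has < 10 nM in this assay as a limit of the assay, not a number. Compound 4 `Cc1cc(C)c2c(O)cc(-c3cccc4ccccc34)nc2n1` differs from compound 3 by a methyl in place of hydrogen on an aromatic carbon, next to the ring nitrogen (methyl in place of hydrogen on an aromatic carbon). Among the compounds with values here, no measured pair isolates this change. In this assay no step beyond the scatter is expected, with any drift toward weaker inhibition of growth. This expectation leans on compound 1 with 15.9 nM in the same low range, though compound 2 with 3800 nM shows how far values in the series can lie apart. The expected size is an estimated at least 1.2-fold higher number from compound 3 to compound 4 (0.07 log units; that floor lies within the scatter) for this change. Compound 4 is estimated at 12 nM with an expected range of 3 nM to 60 nM in this assay.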

Compound 4, concentration for 50% growth inhibition: 380 nM
Estimate against measurement, compound 4: 32-fold (1.50 log units) below; measured number above the stated range.
By their numbers in this assay, from the lowest: compound 1; then compound 4; then compound 2. At a limit, below all of these: compound 3.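

In this assay, this position does not tolerate every change: a methyl in place of hydrogen on an aromatic carbon, next to the ring nitrogen, gives an at least 38-fold higher number from compound 3 to compound 4 (1.57 log units; beyond the scatter). Within the data shown here, this is the only step that isolates one change, and it runs toward weaker inhibition of growth. Compound 3 stands at a limit, so the size of the step is a floor: the limit of < 10 nM in this assay, at which 1 of the 4 values shown sits.

On these data alone, whether any group at this position has a similar effect, for example an amine or a longer chain, remains open. Also open, as far as these compounds go, is whether the same methyl would shift the value of compound 1 to a similar extent.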